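This account rests on a few compounds, and the source may have more. Where it says the series, first, only, none or still open, it means among the compounds named here.

Working notes on the urea series. In an ADME assay on HEK293 cells (Homo sapiens) for cytotoxicity, with a stated time of 72 h (a higher number here means that more compound is needed for the effect, a lower number that less compound is needed), compound 1 `CC(=O)c1ccc(NC(=O)Nc2cc(C)nc3ccccc23)cc1` gives only a limit of the assay, > 25000 nM. Compound 2 `CSc1ccc(NC(=O)Nc2cc(C)nc3ccccc23)cc1` gives 24000 nM in this assay. Compound 3 `COc1ccc(NC(=O)Nc2cc(C)nc3ccccc23)cc1Cl` gives 26000 nM in this assay. Compound 2 and compound 3 sit within the scatter of each other, and the third value shown is a limit, so compound 2 has no separable standing among the numbers. Going by the values given here, the only measured step, an at least 1.0-fold lower number from compound 1 to compound 2 (0.01 log units; that floor lies within the scatter), rests on the limit of > 25000 nM in this assay, at which 1 of the 3 values shown sits, and shows nothing beyond the scatter.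

Compound 4 `CCc1ccc(NC(=O)Nc2cc(C)nc3ccccc23)cc1` differs from compound 2 as follows: ethyl in place of methylsulfanyl on an aromatic carbon. Among the compounds with values here, no measured step covers this exchange; the single step available did not move the number beyond the scatter, and the three values on this ring cluster closely. The step from compound 2 to compound 4 is therefore expected to be a 1.0-fold higher number from compound 2 to compound 4 (0.02 log units; within the scatter), nothing beyond the scatter. For compound 4 the estimate in this assay is 25000 nM, with a range from 12000 nM to 50000 nM.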

Compound 4, half-maximal effective concentration: 16000 nM
Beside the measured number, compound 4's estimate is 1.6-fold (0.19 log units) above it, and the stated range covers the measured number.
By their numbers in this assay, from the lowest: compounds 4, 2 and 3 (each within the scatter of the next).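

Ethyl in place of methylsulfanyl on this aromatic carbon, para to a large group, gives a 1.5-fold lower number from compound 2 to compound 4 (0.18 log units; within the scatter) in this assay. The exchange thus removes the sulfur and the hydrogen-bond acceptor of the methylsulfanyl group without a change separable from the scatter. The earlier step, from acetyl to methylsulfanyl, did not cover this case. Ethyl is the only group of carbon alone among these. The comparison with the acetyl group gives an at least 1.5-fold lower number from compound 1 to compound 4 (0.19 log units; that floor lies within the scatter), which is only a floor set by a limit of the assay: the limit of > 25000 nM in this assay, at which 1 of the 4 values shown sits.

As far as these compounds go, whether an amine, a carboxylic acid or a longer chain at this position would move the number beyond the scatter stays open. The compounds shown also leave open whether any exchange at this carbon can separate from the others in this assay.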